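Fluoro for methoxy on the outer ring of compound 1

The compounds below may be only part of what the source reports. "The series", "measured", "known", "first", "only" and "open" are said of these compounds alone.

Within the data shown here, compound 1 `COc1ccc(-c2ccc(-c3ccc(C(=N)N)o3)o2)cc1` stands at the lower of the two numbers so far: in a functional assay on MDA-MB-435 cells (Homo sapiens) for inhibition, read by sulforhodamine B assay, with a stated time of 48 h (on this read-out lower numbers stand for stronger inhibition of growth and higher numbers for weaker inhibition of growth), compound 1 gives 290 nM, while compound 2 `N=C(N)c1ccc(-c2ccc(-c3ccc4ccccc4c3)s2)s1` gives 1910 nM, a gap beyond the scatter; the two differ in several places, so only the pair of values is read from it. Compound 3 `N=C(N)c1ccc(-c2ccc(-c3ccc(F)cc3)o2)o1` differs from compound 1 by fluoro in place of methoxy on an aromatic carbon. Among the measured compounds shown here, no measured pair isolates this change, so a small step is expected, within or near the scatter, leaning weaker. For compound 3 the expected value is 450 nM (150 nM to 1400 nM), a step of a 1.6-fold higher number from compound 1 to compound 3 (0.19 log units; within the scatter).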

Compound 3, concentration for 50% growth inhibition: 350 nM
Estimate against measurement, compound 3: 1.3-fold (0.11 log units) above; the measured number falls inside the stated range.
By their numbers in this assay, from the lowest: compounds 1 and 3 (each within the scatter of the next); then compound 2.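

Among these compounds, this is the first pair that differs in one place: in this assay, fluoro in place of methoxy on an aromatic carbon, para to a large group, gives a 1.2-fold higher number from compound 1 to compound 3 (0.08 log units; within the scatter). At this position, the hydrogen-bond acceptor counted in methoxy can therefore be lost without a step beyond the scatter. Nothing available explains this result.

Open, from the compounds shown here alone, is whether an amine or a carboxylic acid at this position would also stay within the scatter of compound 1. Also open, going by these compounds, is whether fluoro in place of methoxy reads the same on the core of compound 2.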